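Methoxy for chloro on the aryl group of compound 3

A few compounds are considered here, and "the series" means these few. Any claim that something is new, unique, unknown or untested is made for them only; others in the source may bear on it.

The measured compounds in a functional assay on HL-60 cells (Homo sapiens) for antiproliferative activity, with a stated time of 72 h; a higher number here means a weaker inhibitor, a lower number a stronger inhibitor:
compound 1, `CCCC#Cc1cc([C@@H]2O[C@H](CO)[C@@H](O)[C@H]2O)n2ncnc(N)c12`, gives 200 nM.
compound 2, `Nc1ncnn2c([C@@H]3O[C@H](CO)[C@@H](O)[C@H]3O)cc(C#Cc3ccccc3)c12`, gives only a limit, > 100000 nM.
compound 3, `Nc1ncnn2c([C@@H]3O[C@H](CO)[C@@H](O)[C@H]3O)cc(-c3ccc(Cl)cc3)c12`, gives 37900 nM.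

Compound 3 stands at the highest of the two numbers; compound 1 lies far lower, a 190-fold higher number from compound 1 to compound 3 (2.28 log units; beyond the scatter), and compound 2 sits at a limit, (the limit of > 100000 nM in this assay, at which 1 of the 3 values shown sits). Compound 4, `COc1ccc(-c2cc([C@@H]3O[C@H](CO)[C@@H](O)[C@H]3O)n3ncnc(N)c23)cc1`, differs from compound 3 by methoxy in place of chloro on an aromatic carbon. Within the data shown here, none of the measured steps touches this group: an at least 500-fold higher number from compound 1 to compound 2 (2.69 log units; beyond the scatter) and a 190-fold higher number from compound 1 to compound 3 (2.28 log units; beyond the scatter) both replace the pent-1-yn-1-yl side, and an at least 2.6-fold lower number from compound 2 to compound 3 (0.42 log units; beyond the scatter) exchanges the whole substituent. So no step beyond the scatter is expected, a 1.1-fold lower number from compound 3 to compound 4 (0.03 log units; within the scatter). Compound 4 is therefore expected near 35000 nM, between 9000 nM and 130000 nM.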

Compound 4, half-maximal inhibitory concentration: > 100000 nM
Compound 4 ended at the assay's limit; the forecaster's own chance of this, stated with the estimate: 25%; middle value at least 2.8-fold (0.45 log units) away from the limit.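

In this assay, the group on the aryl ring is not a silent spot: with methoxy in place of chloro there is an at least 2.6-fold higher number from compound 3 to compound 4 (0.42 log units; beyond the scatter). Compound 4 gives > 100000 nM, which is a limit of the assay. Replacing pent-1-yn-1-yl with 4-methoxyphenyl gives an at least 500-fold higher number from compound 1 to compound 4 (2.69 log units; beyond the scatter), so this aryl compound, like compound 3, stays far from compound 1.

From the compounds shown here alone, the step between compound 2 and compound 4 cannot be read, as both values are limits: the limit of > 100000 nM in this assay, at which 2 of the 4 values shown sit. How an amine or a carboxylic acid on this aryl ring would read stays open.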